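Widening the ring on the carbonyl carbon of compound 3

The compounds below may be only part of what the source reports. "The series", "measured", "known", "first", "only" and "open" are said of these compounds alone.

Compound 1 `CC(=O)c1cc(C(=O)O)c(Nc2ccc(I)cc2F)n1C`: 2.05 h
Compound 2 `CC(=O)c1cc(C(=O)NOCCCO)c(Nc2ccc(I)cc2F)n1C`: 0.717 h
Compound 3 `CC(=O)c1cc(C(=O)N2CC(O)C2)c(Nc2ccc(I)cc2F)n1C`: 0.25 h

These half-lives come from an in vitro ADME assay on microsomes from liver (Homo sapiens) for metabolic stability; on this read-out higher numbers stand for a longer-lived compound and lower numbers for a shorter-lived compound. Compound 3 has the lowest number of the three, at 0.25 h. Compound 4 `CC(=O)c1cc(C(=O)N2CC[C@@H](O)C2)c(Nc2ccc(I)cc2F)n1C` has not yet been measured. It keeps the shared core and differs from compound 3 at one place, on a carbonyl carbon: 3-hydroxypyrrolidin-1-yl in place of 3-hydroxyazetidin-1-yl on a carbonyl carbon. In words, 3-hydroxypyrrolidin-1-yl stands in place of 3-hydroxyazetidin-1-yl.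

All three measured steps are changes at this same carbonyl carbon. They are a 2.9-fold lower number from compound 1 to compound 2 (0.46 log units; beyond the scatter), a 2.9-fold lower number from compound 2 to compound 3 (0.46 log units; beyond the scatter) and an 8.2-fold lower number from compound 1 to compound 3 (0.91 log units; beyond the scatter), each modest but beyond the scatter. So the group at this place can clearly move the number in this assay. However, these steps swap quite different groups, and none of them compares two ring sizes, so they give only a loose guide here. The swap in compound 4 is a smaller one, and the nearest neighbour of compound 3 is compound 2, which lies higher at 0.717 h. A slight lean upward is therefore expected, but no clear step beyond the scatter. The estimated step is a 1.4-fold higher number from compound 3 to compound 4 (0.15 log units; within the scatter). For compound 4 the estimated half-life is 0.35 h, with an expected range from 0.15 h to 0.8 h.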

Compound 4, half-life: 0.233 h
Compound 4: middle estimate off by 1.5-fold (0.18 log units), on the high side; the measured number falls inside the stated range.
By their numbers in this assay, from the lowest: compounds 4 and 3 (each within the scatter of the next); then compound 2; then compound 1.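

In this assay, for the compounds shown here, the step of a 1.1-fold lower number from compound 3 to compound 4 (0.03 log units; within the scatter) is the first direct comparison of two ring sizes on this carbonyl carbon, and it shows that 3-hydroxypyrrolidin-1-yl and 3-hydroxyazetidin-1-yl cannot be told apart on this read-out. Compound 4 also keeps the wide gaps seen for compound 3, with a 3.1-fold lower number from compound 2 to compound 4 (0.49 log units; beyond the scatter) and an 8.8-fold lower number from compound 1 to compound 4 (0.94 log units; beyond the scatter), so among these compounds the clear steps come with replacing hydroxy or (3-hydroxypropoxy)amino by one of the two rings, while the ring size shown here makes no clear difference. Nothing measured here explains why the half-lives of these compounds fall where they do.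

The compounds shown cannot tell whether this holds for a larger ring, such as 4-hydroxypiperidin-1-yl, or for a plain pyrrolidin-1-yl ring that carries no hydroxy group. They also leave open whether the mirror-image form of the 3-hydroxypyrrolidin-1-yl group would give a half-life close to that of compound 4.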